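The source may hold more compounds than are shown below. What is called first, only, known or untested is meant among the compounds shown, and "the series" means these compounds.

Three compounds have been measured, all in a functional assay on the whole organism (Pleural cavity) for inhibition, with Rattus norvegicus as the target, at a dose of 25 mg/kg; a higher number here means more inhibition at the dose given (going by the name of the read-out), a lower number less inhibition:
Compound 1, `CC1(Sc2ccccc2)C(=O)N(c2ccccc2)c2ncccc21`, gives 0% in this assay.
Compound 2, `CC1(C)C(=O)N(c2ccccc2Cl)c2ncccc21`, gives 14% in this assay.
Compound 3, `CC1(C)C(=O)N(Cc2ccccc2)c2ncccc21`, gives 12% in this assay.

Compound 1 stands lowest of the three. Its nearest neighbour on the numbers is compound 3, whose value lies higher by a gap beyond the usual scatter; compound 2 lies further off, also beyond the scatter. Compound 1 therefore has the lowest number of the three as measured. No pair among these three differs in only one place, so their values are compared here without any single change being assigned to the gaps between them.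

The next compound, compound 4, `COCCSC1(C)C(=O)N(c2ccccc2)c2ncccc21`, has not yet been measured. It differs from compound 1 in one place: 2-methoxyethyl in place of phenyl on a sulfur. Within the data shown here, no measured pair in this set shows the same change, so the expected size of the step rests only on the low value of compound 1 and on the modest spread across the three compounds. In this assay no step beyond the scatter is expected, with any movement more likely upward than downward, since compound 1 sits at the floor of the read-out. Compound 4 is expected to give about 8%, within a range from 0% to 22%. The step from compound 1 to compound 4 that this estimate means, a number 8 percentage points higher from compound 1 to compound 4 (within the scatter), is expected to stay within the scatter.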

Compound 4, a percentage reported as inhibition, in the whole organism at one dose (the size of the read-out at that dose, not a potency): 26%
The estimate for compound 4 lay 18 percentage points below the measured number; the measured number lies above the stated range.
By their numbers in this assay, from the lowest: compound 1; then compounds 3 and 2 (each within the scatter of the next); then compound 4.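

The group on the sulfur proves to be a position to which this assay responds: 2-methoxyethyl in place of phenyl gives a number 26 percentage points higher from compound 1 to compound 4 (beyond the scatter), on an otherwise unchanged structure. An aromatic ring on that sulfur is therefore not needed for compound 4 to read above compound 1, which gives 0% here. Nothing available accounts for this step.

The 2-methoxyethyl group differs from phenyl both in having no ring and in carrying an oxygen, and the compounds shown do not separate these two differences. Going by these compounds, it also remains open how a plain alkyl chain, a longer ether chain or an amine on the same sulfur would read, and whether the step would persist on a different group at the ring nitrogen.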